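Quinoline amine series: acid dissociation and the distal aryl group

This account rests on a few compounds, and the source may have more. Where it says the series, first, only, none or still open, it means among the compounds named here.

Compound 1 `c1ccc(Oc2ccc3c(NCCCNCc4ccco4)ccnc3c2)cc1` gives 9.28 in a physicochemical assay for acid dissociation. Compound 2 `COc1cccc(CNCCCNc2ccnc3cc(Oc4ccc(Cl)cc4)ccc23)c1O` gives 9.28 and compound 3 `CC(C)(C)c1ccc(Oc2ccc3c(NCCCNCc4ccco4)ccnc3c2)cc1` gives 9.28, so compound 1 stands level with both at the digits shown; its nearest neighbour is compound 2 and its furthest compound 3, neither separated beyond the scatter. Going by the values given here, the only single-point step measured, no change at the digits printed from compound 1 to compound 3 (within the scatter), shows no change within the scatter.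

Compound 4 `COc1ccc(-c2ccc3c(NCCCNCc4ccco4)ccnc3c2)cc1` differs from compound 1 by 4-methoxyphenyl in place of phenoxy on an aromatic carbon. The measured step bearing on this change, no change at the digits printed from compound 1 to compound 3 (within the scatter), altered the same distal ring without effect, and compound 2 with a different distal ring sits at the same level. No step beyond the scatter is therefore expected in this assay. Compound 4 is estimated at 9.28, between 8.95 and 9.6, a step of no change at the digits printed from compound 1 to compound 4 (within the scatter).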

Compound 4, acid dissociation constant: 9.47
Compound 4: the middle estimate sits 0.19 log units below what was measured; the measured number falls inside the stated range.
By their numbers in this assay, from the lowest: compounds 1, 2, 3 and 4 (each within the scatter of the next).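

In this assay, 4-methoxyphenyl in place of phenoxy on this aromatic carbon gives a number 0.19 log units higher from compound 1 to compound 4 (within the scatter). The step from compound 1 to compound 3 touched only a hydrogen on the distal ring, whereas compound 4 replaces the phenoxy group itself, so the read-out now holds within the scatter across a change of the whole group at this position. No supporting measurement bears on why the read-out holds. Open, as far as these compounds go, is whether a group of a different kind on this carbon, such as an amine or a carboxylic acid, would also leave the read-out within the scatter.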